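Working notes: from compound 1 to compound 4

The source may report more compounds than this note shows. Statements on the series, on what has been measured and on what is new or still open speak of the compounds shown alone.

Measured so far in a functional assay on K562 cells (Homo sapiens) for inhibition, read by fluorescence, with a stated time of 72 h (on this read-out lower numbers stand for stronger inhibition of growth and higher numbers for weaker inhibition of growth), for this series:
compound 1 `COc1ccc(Nc2nc(N[C@H]3CC[C@H](N)CC3)nc3c2ncn3CCC(C)C)c(OC)c1` gives 5500 nM
compound 2 `CCCCCCn1cnc2c(Nc3ccc(Cl)cc3)nc(N[C@H]3CC[C@H](N)CC3)nc21` gives 2100 nM
compound 3 `CC(C)=CCn1cnc2c(Nc3cccc(Cl)c3)nc(N[C@H]3CC[C@H](N)CC3)nc21` gives 3500 nM

Compound 1 stands at the upper end of this small set. Compound 1 at 5500 nM and compound 3 at 3500 nM lie within the scatter of each other. Compound 2 at 2100 nM is lower than compound 1 by more than the scatter.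

The next compound is compound 4 `CC(C)CCn1cnc2c(NCc3cccc(Cl)c3)nc(N[C@H]3CC[C@H](N)CC3)nc21` and it has 3-chlorobenzyl in place of 2,4-dimethoxyphenyl on a nitrogen on an aromatic ring. The counted difference 3-chlorobenzyl in place of 2,4-dimethoxyphenyl on a nitrogen on an aromatic ring is the whole change from compound 1.

Within the data shown here, no pair measured so far differs in one place, and none carries a benzyl group, so the guidance is thin. Compound 2 at 2100 nM and compound 3 at 3500 nM both hold chlorine in the group on that nitrogen, but they also differ from compound 1 in the chain. On that loose basis, the expected change in this assay is a modest move toward a lower number, estimated as a 2.2-fold lower number from compound 1 to compound 4 (0.34 log units; beyond the scatter) and not far beyond the scatter. For compound 4 the estimated value is 2500 nM with an expected range from 800 nM to 7000 nM in this read-out.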

Compound 4, concentration for 50% growth inhibition: 3100 nM
Beside the measured number, compound 4's estimate is 1.2-fold (0.09 log units) below it; low and high end bracket the measured number.
By their numbers in this assay, from the lowest: compounds 2, 4, 3 and 1 (each within the scatter of the next, the first and the last beyond it).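

In this assay, among these compounds, the only pair that differs in one place gives a 1.8-fold lower number from compound 1 to compound 4 (0.25 log units; within the scatter), a step that stays within the scatter. Among the compounds shown here, this is the first reading at this position with the rest of the molecule held constant: with the chain and the shared core unchanged, a substantial exchange on the nitrogen, in which the two oxygen atoms leave and a chlorine enters as part of 3-chlorobenzyl, does not move the number beyond the scatter. No measured information on the compounds accounts for the size of this step, so it stands as an observation without an explanation.

The exchange alters the methoxy groups, the chlorine and the benzyl link together, so the step cannot be divided among these features, and one pair cannot show whether the same exchange would read alike on another chain. As far as these compounds go, it remains open whether an unsubstituted benzyl or a 2,4-dimethoxybenzyl group on this nitrogen, or an amine or a carboxylic acid on the benzyl ring, would give a number beyond the scatter from that of compound 4.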